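Swapping a Furan for a Chlorophenyl Sulfide on a Shared Core

The source may report more compounds than this note shows. Statements on the series, on what has been measured and on what is new or still open speak of the compounds shown alone.

Of the compounds shown here, two built on the same fused core have been tested for how much they harm human cells. Compound 1 `Cc1cc(-n2ccnc2)cn2c(CSCCc3ccccc3)cnc12` and compound 2 `Cc1cc(-c2ccoc2)c2ncc(CSCCc3ccccc3)n2c1` were both run in an ADME assay on HEL cells (Homo sapiens) for cytotoxicity, with a stated time of 3 days; on this read-out lower numbers stand for higher toxicity in this test and higher numbers for lower toxicity in this test. In this assay compound 1 gives 100 ug/mL, and compound 2 gives 100 ug/mL. Compound 2 therefore stands level with compound 1 at the digits measured; the two values sit within the scatter of one another, so nothing can be said about an order between them.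

Compound 3 `Cc1cc(Sc2ccc(Cl)cc2)c2ncc(CSCCc3ccccc3)n2c1` has not yet been measured. It differs from compound 2 in one place: (4-chlorophenyl)sulfanyl in place of furan-3-yl on an aromatic carbon. The group that leaves and the group that enters are both counted with one hydrogen-bond acceptor and no charge, but the entering group brings more heavy atoms, a sulfur and a chlorine, and a six-membered ring of carbon only in place of a five-membered ring with one heteroatom.

Among the measured compounds shown here, no step between two measured compounds exists to lean on, so the expectation rests on the two values alone. The step of a 2.0-fold lower number from compound 2 to compound 3 (0.30 log units; within the scatter) is expected to be modest, toward higher toxicity, and may not exceed the scatter. Compound 3 is expected to give 50 ug/mL, within a range from 20 ug/mL to 100 ug/mL.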

Compound 3, minimum cytotoxic concentration: 4 ug/mL
Beside the measured number, compound 3's estimate is 13-fold (1.10 log units) above it; the whole stated range lies above it.
By their numbers in this assay, from the lowest: compound 3; then compounds 1 and 2 (each within the scatter of the next).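

Placing (4-chlorophenyl)sulfanyl instead of furan-3-yl on this aromatic carbon gives a 25-fold lower number from compound 2 to compound 3 (1.40 log units; beyond the scatter) in this assay, which shows that the group held here can shift this read-out well beyond the scatter, toward higher toxicity in this test. The two groups have the same counts of hydrogen-bond donors and acceptors and neither carries a charge, so those counts do not separate them; they differ in heavy atoms, in the presence of sulfur and chlorine, and in ring type. Nothing available here explains why the number falls so far.

This single step changes several features at once, so it cannot say whether the sulfur link, the chlorine or the carbon-only ring accounts for the shift. A phenylsulfanyl group without the chlorine, a 4-chlorophenyl group joined directly to the ring without sulfur, or an amine on the same carbon would each help to pull these features apart, and the shown compounds do not say how any of them would read.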